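Working notes: tert-butyl in place of methyl, compound 4

The source may hold more compounds than are shown below. What is called first, only, known or untested is meant among the compounds shown, and "the series" means these compounds.

Measured in a functional assay on OVCAR-8 cells (Homo sapiens) for inhibition, read by sulforhodamine B assay, with a stated time of 72 h; a higher number here means a weaker inhibitor, a lower number a stronger inhibitor:
compound 1 `CNC1=C(C)C(=O)C=C(C(C)C)C1=O` gives 12900 nM
compound 2 `CC1=CC(=O)C(N(C)C)=CC1=O` gives 5600 nM
compound 3 `CC1=CC(=O)C(C(C)(C)C)=CC1=O` gives 13500 nM

Compound 3 and compound 1 give numbers within the scatter of each other; compound 2 gives a lower number, the step being a 2.4-fold higher number from compound 2 to compound 3 (0.38 log units; beyond the scatter).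

Compound 4 `CC(C)(C)C1=CC(=O)C(C(C)(C)C)=CC1=O` differs from compound 3 by tert-butyl in place of methyl on a double-bonded ring carbon. For the measured compounds named here, no measured step shows a tert-butyl entering for a methyl; the only step in hand, a 2.4-fold higher number from compound 2 to compound 3 (0.38 log units; beyond the scatter), concerns a tert-butyl for a dimethylamino, a different change, so it bears on compound 4 only loosely. No step beyond the scatter is therefore expected in this assay, and compound 4 is estimated at 15000 nM, range 7000 nM to 35000 nM, an expected step of a 1.1-fold higher number from compound 3 to compound 4 (0.05 log units; within the scatter).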

Compound 4, half-maximal inhibitory concentration: 51200 nM
The estimate for compound 4 lay 3.4-fold (0.53 log units) below the measured number, and the stated range ends below it.
By their numbers in this assay, from the lowest: compound 2; then compounds 1 and 3 (each within the scatter of the next); then compound 4.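

On the double-bonded ring carbon three ring bonds from the ring atom that bears a tert-butyl group, tert-butyl in place of methyl gives a 3.8-fold higher number from compound 3 to compound 4 (0.58 log units; beyond the scatter) in this assay. The number at this position therefore moves beyond the scatter with an all-carbon change, whereas the earlier step concerned the other ring carbon. Nothing available accounts for this step.

A single step at this position gives no trend. As far as these compounds go, whether an amine, a carboxylic acid or a longer chain here would lower or raise the number remains open.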